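Replacing the 4-hydroxyphenyl group of compound 3

This account rests on a few compounds, and the source may have more. Where it says the series, first, only, none or still open, it means among the compounds named here.

In a physicochemical assay for solubility, read by spectrophotometry, in phosphate buffer, with a stated time of 18 h, at pH 7.4 (a lower number here means a less soluble compound, a higher number a more soluble compound), compound 1 (`CCc1ccc(-c2nc3c(c(C)nn3-c3ccccc3)c(-c3ccccc3S(C)(=O)=O)c2C#N)cc1`) reads 2200 nM and compound 2 (`CCc1ccc(-c2nc3c(c(C)nn3-c3ccccc3)c(-c3ccccc3C(F)(F)F)c2C#N)cc1`) reads 11000 nM on a shared core. Compound 3 (`CCc1ccc(-c2nc3c(c(C)nn3-c3ccccc3)c(-c3ccc(O)cc3)c2C#N)cc1`) reads 5700 nM on that same core. Two steps fix its place, one that cannot be told from ordinary scatter (a 1.9-fold lower number from compound 2 to compound 3 (0.29 log units; within the scatter)) and one that can (a 2.6-fold higher number from compound 1 to compound 3 (0.41 log units; beyond the scatter)).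

Compound 4 (`C#Cc1ccccc1-c1c(C#N)c(-c2ccc(CC)cc2)nc2c1c(C)nn2-c1ccccc1`) has 2-ethynylphenyl in place of 4-hydroxyphenyl on an aromatic carbon, ortho to a cyano group (2-ethynylphenyl in place of 4-hydroxyphenyl on an aromatic carbon). The three measured compounds differ only in the group on this same carbon, so their steps are the best available guide. Even the widest of them is modest (a 5.0-fold higher number from compound 1 to compound 2 (0.70 log units; beyond the scatter)), and none of them tests an ethynyl group, so the direction stays open. No change beyond the scatter is therefore expected (a 1.2-fold higher number from compound 3 to compound 4 (0.09 log units; within the scatter)). In this assay the expected value for compound 4 is 7000 nM (estimated range 2500 nM to 15000 nM).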

Compound 4, solubility: 46000 nM
Compound 4: the middle estimate sits 6.6-fold (0.82 log units) below what was measured; measured number above the stated range.
By their numbers in this assay, from the lowest: compound 1; then compounds 3 and 2 (each within the scatter of the next); then compound 4.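

In this assay, among these compounds, this carbon allows a much wider spread of numbers than the first three compounds showed, and 2-ethynylphenyl gives the highest number so far (an 8.1-fold higher number from compound 3 to compound 4 (0.91 log units; beyond the scatter)). Among the compounds shown here, the ethynyl group also stands clearly above the trifluoromethyl group on the same phenyl ring (a 4.2-fold higher number from compound 2 to compound 4 (0.62 log units; beyond the scatter)), and its step from the methylsulfonyl group is the first large one at this position (a 21-fold higher number from compound 1 to compound 4 (1.32 log units; beyond the scatter)). No measurement shown here accounts for these rises.

Still open, as far as these compounds go, is whether other groups on this phenyl ring, such as an amine, a carboxylic acid or a longer alkyne chain, would reach a similar number. For the compounds shown here, also open is whether the rise would persist on a different core, since every step here changes only this one group.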